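Cytotoxicity working notes on compounds 1 to 4

The compounds below may be only part of what the source reports. "The series", "measured", "known", "first", "only" and "open" are said of these compounds alone.

Measured compounds:
- compound 1 `COc1ccc(N2CCN(CN3C(=O)/C(=N\NC(=S)NO)c4cc(F)ccc43)CC2)cc1`: 260000 nM
- compound 2 `CCn1cc(C(=O)O)c(=O)c2cc(F)c(N3CCN(CN4C(=O)/C(=N\NC(=S)NO)c5cc(Cl)ccc54)CC3)cc21`: 186000 nM
- compound 3 `CCn1cc(C(=O)O)c(=O)c2cc(F)c(N3CCN(CN4C(=O)/C(=N\NC(=S)NOC)c5cc(C)ccc54)CC3)cc21`: 238000 nM

In an ADME assay on MT4 cells (Homo sapiens) for cytotoxicity, read by spectrophotometry, with a stated time of 5 days (on this read-out lower numbers stand for higher toxicity in this test and higher numbers for lower toxicity in this test), compound 1 gives 260000 nM, the highest of the three numbers. Compound 3 gives 238000 nM and compound 2 gives 186000 nM, and both sit within the scatter of compound 1, so the three measured compounds are not separable on this read-out; none of them can be called more or less toxic than another.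

Compound 4 `CONC(=S)N/N=C1\C(=O)N(CN2CCN(c3ccc(OC)cc3)CC2)c2ccc(F)cc21` is the next compound to be measured. It differs from compound 1 by methyl in place of hydrogen on an oxygen. For the measured compounds named here, no step between two measured compounds covers this change on its own: compound 3 carries a methoxyamino group where compound 2 carries a hydroxyamino group, but these two differ elsewhere as well, and their values lie within the scatter of each other, which shows nothing for or against an effect of the methyl.

With the three measured values all within one band of scatter, the step from compound 1 to compound 4 is expected to be none beyond the scatter, an estimated 1.1-fold lower number from compound 1 to compound 4 (0.03 log units; within the scatter). Compound 4 is therefore expected to give 240000 nM in this assay, with an estimated range from 120000 nM to 480000 nM.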

Compound 4, half-maximal cytotoxic concentration: 276000 nM
Compound 4: the middle estimate sits 1.2-fold (0.06 log units) below what was measured; measured number inside the range.
By their numbers in this assay, from the lowest: compounds 2, 3, 1 and 4 (each within the scatter of the next).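

The pair of compound 1 and compound 4 isolates methyl in place of hydrogen on an oxygen whose other neighbour is an amide-type nitrogen, and in this assay it reads as a 1.1-fold higher number from compound 1 to compound 4 (0.03 log units; within the scatter). The earlier compounds shown here offered hydroxyamino to methoxyamino only together with other differences, whereas here it stands alone on the core of compound 1, and at this position on this core the change does not take the number beyond the scatter. No measurement is available that bears on what lies behind this result.

The step rests on one pair, so it remains open whether the same change stays within the scatter on the core of compound 2, where the only methoxyamino compound shown, compound 3, also differs in a second place. Also open is how this oxygen tolerates a longer chain such as ethyl or a larger group such as benzyl, or an acetyl group, as all four numbers shown fall within one band of scatter.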